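The source may hold more compounds than are shown below. What is called first, only, known or untested is meant among the compounds shown, and "the series" means these compounds.

In a functional assay on MCF7 cells (Homo sapiens) for antiproliferative activity, read by MTT assay, with a stated time of 48 h (a higher number here means a weaker inhibitor, a lower number a stronger inhibitor), compound 1 (`COc1ccc(-c2c(Nc3ccc(C)cc3)c3ccccc3oc2=O)cc1`) gives 65300 nM and compound 2 (`CCOc1ccc(Nc2c(-c3ccc(OC)cc3)c(=O)oc3cc(OC)ccc23)cc1`) gives 24300 nM, the lower of the two numbers, with a gap beyond the scatter. Compound 3 (`COc1ccc(-c2c(Nc3ccc(C)cc3)c3ccc(OC)cc3oc2=O)cc1`) carries methyl in place of ethoxy on an aromatic carbon, para to a large group: methyl in place of ethoxy on an aromatic carbon. Going by the values given here, no measured step isolates this change. A modest move towards a higher number, not clearly beyond the scatter, is expected, and the estimated step is a 1.3-fold higher number from compound 2 to compound 3 (0.12 log units; within the scatter). The expected value in this assay for compound 3 is 32000 nM, with an estimated range of 13000 nM to 75000 nM.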

Compound 3, half-maximal inhibitory concentration: 66900 nM
Beside the measured number, compound 3's estimate is 2.1-fold (0.32 log units) below it; the range from low to high includes it.
By their numbers in this assay, from the lowest: compound 2; then compounds 1 and 3 (each within the scatter of the next).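

In this assay, methyl in place of ethoxy on the aromatic carbon of the anilino ring matters at this position: the change gives a 2.8-fold higher number from compound 2 to compound 3 (0.44 log units; beyond the scatter) and lies beyond the scatter. With methyl held there, methoxy in place of hydrogen on an aromatic carbon of the core gives a 1.0-fold higher number from compound 1 to compound 3 (0.01 log units; within the scatter) and so makes no readable difference. Nothing available bears on the reason for either step.

On these data alone, it remains open whether the methoxy step would read the same with ethoxy in place of methyl. A longer chain such as butoxy, or an amine such as dimethylamino, at this position also remains untested in the compounds shown.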